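A few compounds are considered here, and "the series" means these few. Any claim that something is new, unique, unknown or untested is made for them only; others in the source may bear on it.

In an ADME assay on CHO cells (Cricetulus griseus) for cytotoxicity, read by MTT assay, with a stated time of 24 h (a lower number here means that less compound is tolerated, a higher number that more compound is tolerated), compound 2 (`CC1Cn2c(nc([N+](=O)[O-])c2C#Cc2ccc(CO)cc2)O1`) gives 8770 nM, compound 1 (`Cc1ccc(C#Cc2c([N+](=O)[O-])nc3n2CC(C)O3)cc1`) gives 5470 nM and compound 3 (`CC1Cn2c(nc([N+](=O)[O-])c2C#CC2CC2)O1`) gives 6450 nM. These three numbers lie within the scatter of one another, so compound 2 is not separated from either neighbour.

Compound 4 (`CC1Cn2c(nc([N+](=O)[O-])c2C#Cc2ccc(C(C)(C)C)cc2)O1`), not yet measured, has tert-butyl in place of hydroxymethyl on an aromatic carbon, para to a large group (tert-butyl in place of hydroxymethyl on an aromatic carbon).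

Among the compounds with values here, two measured steps bear on this change. The closer one replaces hydrogen with hydroxy on a saturated chain carbon bound to an aromatic carbon, and it comes to a 1.6-fold higher number from compound 1 to compound 2 (0.21 log units; within the scatter). The other, with cyclopropyl in place of 4-methylphenyl on a triple-bonded carbon, is a much larger change at the same end of the molecule, and it comes to a 1.2-fold higher number from compound 1 to compound 3 (0.07 log units; within the scatter). Both stay within the scatter. Within the data shown here, no measured compound carries tert-butyl, so the size of that group's contribution remains untested and the range has to stay wide.

On these steps, the estimated 1.5-fold lower number from compound 2 to compound 4 (0.16 log units; within the scatter) is expected to stay within the scatter, with a slight lean towards the number of compound 1 at 5470 nM. For compound 4 the expected value in this assay is 6000 nM, with an estimated range of 2800 nM to 12500 nM.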

Compound 4, half-maximal cytotoxic concentration: 6620 nM
Estimate against measurement, compound 4: 1.1-fold (0.04 log units) below, within the range that was stated.
By their numbers in this assay, from the lowest: compounds 1, 3, 4 and 2 (each within the scatter of the next).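

In this assay, hydroxymethyl and tert-butyl on this aromatic carbon, para to a large group, are not separated: the exchange comes to a 1.3-fold lower number from compound 2 to compound 4 (0.12 log units; within the scatter). Methyl and tert-butyl at the same carbon are not separated either, at a 1.2-fold higher number from compound 1 to compound 4 (0.08 log units; within the scatter), so the span from methyl to the four heavy atoms of tert-butyl, and from a group with one hydrogen-bond donor and one acceptor to a group with none, leaves the number within the scatter across compound 1, compound 2 and compound 4, with no compound among these three going against that reading. No measurement at hand gives a reason for this lack of separation.

Still open, as far as these compounds go, is whether an amine, a carboxylic acid or a longer chain such as n-octyl on this aromatic carbon would bring the number beyond the scatter, since all three groups seen here carry no net charge and none extends past four heavy atoms. Also open, from the compounds shown here alone, is whether the same lack of separation would hold with the nitro group of the shared core replaced by a nitrile.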